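A few compounds are considered here, and "the series" means these few. Any claim that something is new, unique, unknown or untested is made for them only; others in the source may bear on it.

Compound 1 `CC(O)(c1ccc(-c2ncc(S(=O)(=O)c3ccc(N)nc3)s2)c(Cl)c1)C(F)(F)F`: < 14 mL.min-1.g-1
Compound 2 `C[C@](O)(c1ccc(-c2ncc(S(=O)(=O)c3ccc(N)nc3)s2)c(Cl)c1)C(F)(F)F`: < 14 mL.min-1.g-1
Compound 3 `CC(C)(O)c1ccc(-c2ncc(S(=O)(=O)c3ccc(N)nc3)s2)c(Cl)c1`: 17 mL.min-1.g-1

All three entries come from an ADME assay (liver) for metabolic stability, with Liver microsome (Rattus norvegicus) as the target, using microsomes and NADPH, with a stated time of 30 min, at 37 degrees C, tested at 1 uM; on this read-out lower numbers stand for slow clearance and higher numbers for fast clearance. The entry for compound 1 is a limit of the assay and not a number. The entry for compound 2 is likewise a limit. Among the compounds with values here, compound 3, at 17 mL.min-1.g-1, is the only compound with a number, so it is the natural reference point.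

Compound 4 `Nc1ccc(S(=O)(=O)c2cnc(-c3ccc(S(N)(=O)=O)cc3Cl)s2)cn1` has sulfamoyl in place of 1-hydroxy-1-methylethyl on an aromatic carbon, meta to a chloro group and para to a large group: sulfamoyl in place of 1-hydroxy-1-methylethyl on an aromatic carbon.

The measured steps that bear on this change are those at the same aromatic carbon. These are an at least 1.2-fold higher number from compound 1 to compound 3 (0.08 log units; that floor lies within the scatter) and an at least 1.2-fold higher number from compound 2 to compound 3 (0.08 log units; that floor lies within the scatter), and both floors lie within the scatter. The remaining step, a step that the two limits leave unreadable from compound 1 to compound 2, gives no size. Within the data shown here, no measured compound carries sulfamoyl, so the size of the new step cannot be read directly from the series.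

No step beyond the scatter is therefore expected in this assay, and the direction is left open. The expected change is a 1.1-fold lower number from compound 3 to compound 4 (0.05 log units; within the scatter). For compound 4 the estimate is 15 mL.min-1.g-1, with an expected range of 8 mL.min-1.g-1 to 30 mL.min-1.g-1. A result reported only as a limit is also expected to be quite possible.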

Compound 4, intrinsic clearance in microsomes: 107 mL.min-1.g-1
For compound 4 the middle estimate is 7.1-fold (0.85 log units) below the measured one, and the stated range ends below it.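

Within the data shown here, the position is not indifferent in this assay: on this aromatic carbon, meta to a chloro group and para to a large group, sulfamoyl in place of 1-hydroxy-1-methylethyl gives a 6.3-fold higher number from compound 3 to compound 4 (0.80 log units; beyond the scatter), the only step at this carbon with a full size. Sulfamoyl in place of 1-hydroxy-1-(trifluoromethyl)ethyl gives an at least 7.6-fold higher number from compound 2 to compound 4 (0.88 log units; beyond the scatter) and likewise an at least 7.6-fold higher number from compound 1 to compound 4 (0.88 log units; beyond the scatter), so the change reads the same way from all three earlier compounds, and compound 4 stands apart from them. The last two steps are floors only, because compounds 1 and 2 each stand at a limit of the assay and not at a number: the limit of < 14 mL.min-1.g-1 in this assay, at which 2 of the 4 values shown sit.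

Among these compounds, with sulfamoyl as the only group of its kind here, it stays open whether the step belongs to that group as a whole or to its nitrogen, and a methylsulfonyl group, a carboxamide or a carboxylic acid on the same aromatic carbon would separate these readings. On these data alone, the step from compound 1 to compound 2 cannot be read, so the weight of the configuration at the saturated chain carbon also stays open.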